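The compounds below may be only part of what the source reports. "The series", "measured", "known", "first", "only" and "open" are said of these compounds alone.

Measured compounds:
Compound 1, `C/C(=N/O)c1ccc(NC(=O)CSc2nc3c([nH]2)c(=O)n(C)c(=O)n3C)cc1`, 5300 nM in a functional assay on MCF7 cells (Homo sapiens) for inhibition, read by MTT assay, with a stated time of 48 h; on this read-out lower numbers stand for stronger inhibition and higher numbers for weaker inhibition.
Compound 2, `C/C(=N/O)c1ccc(NC(=O)CSc2nc3[nH]c(=O)n(C)c(=O)c3[nH]2)cc1`, 9100 nM in this assay.
Compound 3, `Cn1c(=O)c2[nH]c(SCC(=O)c3ccccc3)nc2n(C)c1=O`, 5100 nM in this assay.

Compound 4, `Cn1c(=O)[nH]c2nc(SCC(=O)c3ccccc3)[nH]c2c1=O`, has not yet been measured in this assay. The account treats it as the partner of compound 3 in the same way that compound 2 is the partner of compound 1.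

The change from compound 1 to compound 2 is hydrogen in place of methyl on an aromatic nitrogen. That step gave a 1.7-fold higher number from compound 1 to compound 2 (0.23 log units; within the scatter). The change from compound 3 to compound 4 is hydrogen in place of methyl on an aromatic nitrogen. The place described for this change is the same, word for word, as the place described for the change from compound 1 to compound 2, so the two changes count as the same change made on two different cores. The difference between the core of compound 1 and the core of compound 3 is not broken down here; what can be said is that compound 1 and compound 3 give numbers in this assay that sit within the scatter of each other, and compound 2 sits within the scatter of both.

For compound 4 a step of a 1.7-fold higher number from compound 3 to compound 4 (0.22 log units; within the scatter) in this assay is expected, resting on the step from compound 1 to compound 2, which was a 1.7-fold higher number from compound 1 to compound 2 (0.23 log units; within the scatter). On that basis compound 4 is estimated at 8500 nM in this assay, with an expected range from 4000 nM to 18000 nM.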

Compound 4, half-maximal inhibitory concentration: 11600 nM
Estimate against measurement, compound 4: 1.4-fold (0.14 log units) below; the range from low to high includes it.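

In this assay, hydrogen in place of methyl on an aromatic nitrogen gave a 2.3-fold higher number from compound 3 to compound 4 (0.36 log units; beyond the scatter), and this step can be set beside the one on the other core: the same change on two cores in this assay, a 1.7-fold higher number (0.23 log units; within the scatter) from compound 1 to compound 2 and a 2.3-fold higher number (0.36 log units; beyond the scatter) from compound 3 to compound 4, 1.3-fold (0.12 log units) apart, within the scatter of two such steps. Within these two pairs, then, the change carries over from one core to the other: the number rises in both pairs, and the two steps cannot be told apart in size. Among these compounds, this does not make it a general rule for the series, since it rests on only two cores, only the step on the core of compound 3 lies beyond the scatter, and the numbers say nothing about why the change acts as it does.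

The compounds shown leave open what a larger group on that aromatic nitrogen, such as an ethyl group or a longer chain, would do to the number, as they carry only methyl or hydrogen there. As far as these compounds go, it also remains open whether the step would keep its direction and size on a core whose side chain bears an amine or a carboxylic acid.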